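The source may report more compounds than this note shows. Statements on the series, on what has been measured and on what is new or still open speak of the compounds shown alone.

The measured compounds and their numbers in an assay for inhibition of RAC-alpha serine/threonine-protein kinase (Homo sapiens), read by HTRF, with a stated time of 1 h; on this read-out lower numbers stand for stronger inhibition and higher numbers for weaker inhibition:
Compound 1, `Cn1ncc(Cl)c1-c1cc(C(=O)N[C@@H]2CN[C@H](CC(O)CO)C[C@H]2c2ccc(F)c(F)c2)oc1Cl`, gives 3.31 nM.
Compound 2, `Cn1ncc(Cl)c1-c1cc(C(=O)N[C@@H]2CN[C@H](CC(O)CO)C[C@H]2c2ccc(Cl)c(Cl)c2)oc1Cl`, gives 3.79 nM.
Compound 3, `Cn1ncc(Cl)c1-c1cc(C(=O)N[C@@H]2CN[C@H](CCO)C[C@H]2c2ccc(F)c(F)c2)oc1Cl`, gives 0.98 nM.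

Compound 2 stands at the highest of the three numbers in this assay, although it lies within the scatter of compound 1: a 1.1-fold higher number from compound 1 to compound 2 (0.06 log units; within the scatter). Compound 3 gives the lowest number of the set, with a 3.4-fold lower number from compound 1 to compound 3 (0.53 log units; beyond the scatter).

Compound 4, `C=CC[C@@H]1C[C@@H](c2ccc(Cl)c(Cl)c2)[C@H](NC(=O)c2cc(-c3c(Cl)cnn3C)c(Cl)o2)CN1`, has not yet been measured. It differs from compound 2 in one place: vinyl in place of 1,2-dihydroxyethyl on a saturated chain carbon bound to a saturated ring carbon. The change replaces a group carrying two hydrogen-bond donors and two hydrogen-bond acceptors by a vinyl that carries none.

Within the data shown here, only one measured step bears on this change: a 3.4-fold lower number from compound 1 to compound 3 (0.53 log units; beyond the scatter), where a hydrogen replaced a hydroxymethyl on the same chain and the number fell modestly. Among the measured compounds shown here, no measured pair covers removal of the whole 1,2-dihydroxyethyl group, so the size of the effect is uncertain. The comparison of compound 1 with compound 2 shows that the aryl halogen difference did not move the number, so that part of compound 4 is not expected to matter.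

Compound 4 is therefore expected to give a somewhat lower number than compound 2, a step of about a 2.5-fold lower number from compound 2 to compound 4 (0.40 log units; beyond the scatter). The estimate for compound 4 in this assay is 1.5 nM, with a range from 0.5 nM to 5 nM.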

Compound 4, half-maximal inhibitory concentration: 12.4 nM
Compound 4: the middle estimate sits 8.3-fold (0.92 log units) below what was measured, outside the stated range (above it).
By their numbers in this assay, from the lowest: compound 3; then compounds 1 and 2 (each within the scatter of the next); then compound 4.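

In this assay, the exchange of 2,3-dihydroxypropyl for allyl on the chain at this position gives a 3.3-fold higher number from compound 2 to compound 4 (0.51 log units; beyond the scatter), so removing the oxygen-bearing end of the chain can raise the number as well as lower it. The earlier step on the same chain ran the other way, a 3.4-fold lower number from compound 1 to compound 3 (0.53 log units; beyond the scatter), and the change of aryl halogens that separates the two pairs, a 1.1-fold higher number from compound 1 to compound 2 (0.06 log units; within the scatter), does not account for the opposite directions; shortening or stripping this chain therefore has no single direction across the compounds shown, with compound 3 and compound 4 falling on opposite sides of their parent compounds. No measurement given here bears on what lies behind this reversal.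

The compounds shown leave open whether the rise in compound 4 goes with the loss of the hydroxyl groups or with the entering double bond, a question that a saturated propyl chain at the same place would separate. They also leave open how a chain ending in an amine or a carboxylic acid would read in this assay.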